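A few compounds are considered here, and "the series" means these few. Any claim that something is new, unique, unknown or untested is made for them only; others in the source may bear on it.

- compound 1 `COc1ccc(/C=C/C(=O)Nc2cc(-c3ccc(Br)cc3)[nH]n2)cc1` gives 770 nM
- compound 2 `O=C(/C=C/c1ccc(Br)cc1)Nc1cc(-c2ccc(Br)cc2)[nH]n1` gives 1280 nM
- compound 3 `Cc1ccc(-c2cc(NC(=O)/C=C/c3ccc(C(F)(F)F)cc3)n[nH]2)cc1` gives 1210 nM

All three numbers come from a functional assay on B16-F10 cells (Mus musculus) for antiproliferative activity, read by MTT assay, with a stated time of 48 h (a lower number here means a stronger inhibitor, a higher number a weaker inhibitor), and compound 2 sits within the scatter of both compound 1 and compound 3, so no order can be read among these pairs. Compound 4 `O=C(/C=C/c1ccccc1)Nc1cc(-c2ccc(Br)cc2)[nH]n1` differs from compound 2 by one change (hydrogen in place of bromo on an aromatic carbon) in which hydrogen stands in place of bromo on an aromatic carbon. For the measured compounds named here, the one measured step at that place is bromo in place of methoxy, which gave a 1.7-fold higher number from compound 1 to compound 2 (0.22 log units; within the scatter) and so compound 4 is expected to show no step beyond the scatter in this assay in either direction. Compound 3 differs from compound 2 in more than one place and offers no clean comparison. The expected size is a 1.1-fold lower number from compound 2 to compound 4 (0.03 log units; within the scatter) and nothing firmer can be said. For compound 4 the estimated value is 1200 nM with an expected range from 500 nM to 2900 nM for repeated measurements.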

Compound 4, half-maximal inhibitory concentration: 1270 nM
Estimate against measurement, compound 4: 1.1-fold (0.02 log units) below; the measured number falls inside the stated range.
By their numbers in this assay, from the lowest: compounds 1, 3, 4 and 2 (each within the scatter of the next).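

With hydrogen on this aromatic carbon, para to a large group, the position now has an unsubstituted comparison: hydrogen for bromo gives a 1.0-fold lower number from compound 2 to compound 4 (0.00 log units; within the scatter) and hydrogen for methoxy gives a 1.6-fold higher number from compound 1 to compound 4 (0.22 log units; within the scatter) in this assay. Neither bromo nor methoxy can therefore be told apart from plain hydrogen here, so the antiproliferative activity of these compounds does not visibly depend on either group. No measurement on hand offers an explanation for this.

Going by these compounds, whether an amine or a carboxylic acid at this place would move the number beyond the scatter remains open. So does whether the same holds when the other end of the molecule changes.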